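Acid to amide at the chain end of compound 1

The source may hold more compounds than are shown below. What is called first, only, known or untested is meant among the compounds shown, and "the series" means these compounds.

Among the compounds with values here, compound 1 `O=C(O)CCCCCCn1nc(-c2ccccc2)c(-c2ccccc2)c1-c1ccccc1` is the one compound of the three with a number rather than a limit: in a functional assay for inhibition, with Homo sapiens as the target (a lower number here means a stronger inhibitor, a higher number a weaker inhibitor), compound 1 gives 22400 nM. Compound 2 `O=C(O)CCCCCCCCn1nc(-c2ccccc2)c(Cc2ccccc2)c1-c1ccccc1` reaches only a limit of the assay, > 68000 nM. Compound 3 `O=C(O)CCCCCCn1cc(-c2ccccc2)c(-c2ccccc2)n1` likewise reaches only a limit, > 92000 nM. Within the data shown here, the single measured step, an at least 4.1-fold higher number from compound 1 to compound 3 (0.61 log units; beyond the scatter), concerns a phenyl on the core and not the chain. Compound 4 `NC(=O)CCCCCCCCn1nc(-c2ccccc2)c(-c2ccccc2)c1-c1ccccc1` differs from compound 1 in one place: 2-carbamoylethyl in place of carboxy on a saturated chain carbon, six bonds along the chain from an aromatic nitrogen. No measured step covers this change, so nothing shown sets its size or direction. The estimate for compound 4 in this assay is 45000 nM, within 12000 nM to 200000 nM, with a fair chance of a limit only. This expected value corresponds to a step of a 2.0-fold higher number from compound 1 to compound 4 (0.30 log units; within the scatter).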

Compound 4, half-maximal inhibitory concentration: 33000 nM
For compound 4 the middle estimate is 1.4-fold (0.13 log units) above the measured one; the range from low to high includes it.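

In this assay the step reads a 1.5-fold higher number from compound 1 to compound 4 (0.17 log units; within the scatter), so at this chain position 2-carbamoylethyl can stand in place of carboxy with no change beyond the scatter, and compound 4 still gives a number rather than a limit. Within the data shown here, the one earlier step, on a phenyl of the core, lay beyond the scatter; this one at the chain end does not. Nothing shown bears on the cause of this result.

This change swaps the end group and extends the chain together, and the compounds shown do not separate the two. On these data alone, how an amine at the chain end would read also stays open.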